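Working notes: fluoro step from compound 2

The compounds below may be only part of what the source reports. "The series", "measured", "known", "first", "only" and "open" are said of these compounds alone.

Measured so far:
- compound 1 (`Cc1cc(CN(CC2CC2)[C@@H](CC(=O)O)c2ccc(Cl)cc2)ccc1OCCN1C(=O)CCC1=O`): 87%
- compound 2 (`COc1cc(CN(CC(C)C)C(CC(=O)O)c2ccc(Cl)cc2)ccc1OCCN1C(=O)CCC1=O`): 69%

In an ADME assay on liver (Mus musculus) for metabolic stability, read by LC-MS, using microsomes and NADPH (a lower number here means that less of the compound is left, a higher number that more of the compound is left), compound 2 holds the lower of the two numbers (69%) and compound 1 stands higher (87%), a gap beyond the scatter.

The next compound is compound 3 `COc1cc(CN(CC(C)C)C(CC(=O)O)c2ccc(Cl)c(F)c2)ccc1OCCN1C(=O)CCC1=O`, not yet measured. Its difference from compound 2 is fluoro in place of hydrogen on an aromatic carbon and it turns the 4-chlorophenyl into 4-chloro-3-fluorophenyl: fluoro in place of hydrogen on an aromatic carbon, ortho to a chloro group.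

Going by the values given here, no measured pair shows a step of this kind, so nothing yet gives its size directly. The expectation therefore starts from compound 2 at 69% and from the single added fluoro. In this assay no step beyond the scatter is expected, in either direction. The estimated move is a number 2 percentage points higher from compound 2 to compound 3 (within the scatter) and it is expected to stay within the scatter. For compound 3 the expected value is 71% with an estimated range from 56% to 85% on measurement.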

Compound 3, percent of the compound remaining: 57%
For compound 3 the middle estimate is 14 percentage points above the measured one, within the range that was stated.
By their numbers in this assay, from the lowest: compound 3; then compound 2; then compound 1.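

In this assay, fluoro in place of hydrogen on an aromatic carbon, ortho to a chloro group, gives a number 12 percentage points lower from compound 2 to compound 3 (beyond the scatter), so this position on the 4-chlorophenyl responds to a change of a single heavy atom. Going by these compounds alone, this is the first step that can be read at one place, as compound 1 and compound 2 differ in more than one place and their gap could not be assigned to any part of either structure. No measurement shown here explains the step, so the result stays an observation about this change on the scaffold of compound 2.

On these data alone, it remains open whether the lower number belongs to fluoro itself or would also follow from a chloro, a methyl or a nitrile at the same place on the ring. As far as these compounds go, it also remains open whether the same 4-chlorophenyl to 4-chloro-3-fluorophenyl change would give a step of similar size on the core of compound 1, which carries a methyl group and a cyclopropylmethyl group in place of the methoxy and isobutyl groups of compound 2.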